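Combining the benzyl and trifluoromethyl changes in one compound

A few compounds are considered here, and "the series" means these few. Any claim that something is new, unique, unknown or untested is made for them only; others in the source may bear on it.

Compound 1 `CCCCCCC1(O)C(=O)Nc2ccc(Nc3ccc(C)cc3)cc21` serves as the reference; in a functional assay on A549 cells (Homo sapiens) for antiproliferative activity, read by MTT assay, with a stated time of 48 h (a lower number here means a stronger inhibitor, a higher number a weaker inhibitor), compound 1 gives 12100 nM. Compound 2 `Cc1ccc(Nc2ccc3c(c2)C(O)(Cc2ccccc2)C(=O)N3)cc1` differs from compound 1 by phenyl in place of pentyl on a saturated chain carbon bound to a saturated ring carbon; in this assay compound 2 gives 4100 nM, a step of a 3.0-fold lower number from compound 1 to compound 2 (0.47 log units; beyond the scatter). Compound 3 `CCCCCCC1(O)C(=O)Nc2ccc(Nc3ccc(C(F)(F)F)cc3)cc21` carries a different change on the same core, namely (trifluoromethyl in place of methyl on an aromatic carbon); in this assay compound 3 gives 2800 nM, a step of a 4.3-fold lower number from compound 1 to compound 3 (0.64 log units; beyond the scatter). Compound 3 shows the lowest of the three numbers, but its gap to compound 2 lies within the scatter, so no order between those two is claimed.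

Compound 4 `O=C1Nc2ccc(Nc3ccc(C(F)(F)F)cc3)cc2C1(O)Cc1ccccc1` has not been measured. It differs from compound 3 by phenyl in place of pentyl on a saturated chain carbon bound to a saturated ring carbon. The place of this change is the same as for the change from compound 1 to compound 2, so it is the same change made on the core of compound 3 rather than on the core of compound 1. The expected step from compound 3 to compound 4 is a 2.5-fold lower number from compound 3 to compound 4 (0.41 log units; beyond the scatter), resting on the measured step of a 3.0-fold lower number from compound 1 to compound 2 (0.47 log units; beyond the scatter), with some allowance for the two changes not adding fully. Compound 4 is therefore estimated at 1100 nM, expected between 450 nM and 2700 nM.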

Compound 4, half-maximal inhibitory concentration: 2000 nM
The estimate for compound 4 lay 1.8-fold (0.26 log units) below the measured number; the measured number falls inside the stated range.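

In this assay, phenyl in place of pentyl gives a 1.4-fold lower number from compound 3 to compound 4 (0.15 log units; within the scatter), and this step does not differ from the one on the core of compound 1 by more than two such steps can scatter: the same change on two cores in this assay, a 3.0-fold lower number (0.47 log units; beyond the scatter) from compound 1 to compound 2 and a 1.4-fold lower number (0.15 log units; within the scatter) from compound 3 to compound 4, 2.1-fold (0.32 log units) apart, within the scatter of two such steps

Trifluoromethyl in place of methyl gives a 2.1-fold lower number from compound 2 to compound 4 (0.31 log units; beyond the scatter), and this step likewise agrees with its counterpart on the core of compound 1: the same change on two cores in this assay, a 4.3-fold lower number (0.64 log units; beyond the scatter) from compound 1 to compound 3 and a 2.1-fold lower number (0.31 log units; beyond the scatter) from compound 2 to compound 4, 2.1-fold (0.32 log units) apart, within the scatter of two such steps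

Each change therefore carries from one core to the other with no difference in step size that can be resolved, but four compounds do not show that the two changes add exactly, and the phenyl step on the core of compound 3, taken alone, cannot be told from no change.

The compounds shown leave open whether this carrying over extends to a nitrile or an amine in place of trifluoromethyl on an aromatic carbon. From the compounds shown here alone, it is also open whether it holds for a longer chain in place of hexyl or benzyl.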